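Carboxyphenyl swapped for phenylethenyl: expected cytotoxicity

The compounds below may be only part of what the source reports. "The series", "measured", "known", "first", "only" and "open" are said of these compounds alone.

Three close relatives share one core. Compound 1 `COc1ccccc1C1CC(c2cc3ccccc3o2)=NN1C(=O)c1ccncc1` in an ADME assay on Vero cells (Chlorocebus sabaeus) for cytotoxicity, read by MTT assay, with a stated time of 72 h (a higher number here means a weaker inhibitor, a lower number a stronger inhibitor), gives only a limit, > 202000 nM. Compound 2 `O=C(O)c1ccccc1C1CC(c2cc3ccccc3o2)=NN1C(=O)c1ccncc1` likewise reaches a limit in this assay, > 170000 nM. Compound 3 `COc1ccc(C2CC(c3cc4ccccc4o3)=NN2C(=O)c2ccncc2)cc1` also ends at a limit in this assay, > 200000 nM. All three values are limits, so the steps a step that the two limits leave unreadable from compound 1 to compound 2, a step that the two limits leave unreadable from compound 1 to compound 3 and a step that the two limits leave unreadable from compound 2 to compound 3 have no readable size, and compound 2 stands at a limit among two further limits. Compound 4 `O=C(c1ccncc1)N1N=C(c2cc3ccccc3o2)CC1/C=C/c1ccccc1` differs from compound 2 by 2-phenylethenyl in place of 2-carboxyphenyl on a saturated ring carbon. Going by the values given here, no measured step bears a readable size, so no direction is expected in this assay beyond the scatter. Compound 4 is therefore expected to sit again at a limit, estimated at 200000 nM within 60000 nM to 600000 nM. The expected step is a step that the limit leaves unreadable from compound 2 to compound 4.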

Compound 4, half-maximal inhibitory concentration: > 212000 nM
Compound 4 was reported as a limit; the forecaster's own chance of this, stated with the estimate: 70%; middle value at least 1.0-fold (0.02 log units) away from the limit.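

Compound 4 also ends at a limit, > 212000 nM, so its steps from compound 1, compound 2 and compound 3 cannot be read. The compounds shown leave open what value any of them would reach in this assay.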